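The source may hold more compounds than are shown below. What is called first, only, known or untested is meant among the compounds shown, and "the series" means these compounds.

Compound 1 `COc1ccc(SCc2ccc(/C=C/C(=O)Nc3ccccc3N)cc2)cc1OC`: 80.6%
Compound 2 `COc1ccc(SCc2ccc(C(=O)Nc3ccccc3N)cc2)cc1`: 70.7%

Both compounds were tested in a functional assay on A549 cells (Homo sapiens) for inhibition, read by CCK-8 assay, with a stated time of 72 h, tested at 8 uM; a lower number here means less inhibition of growth, a higher number more inhibition of growth at the concentration tested. Compound 2 has the lower of the two numbers at 70.7%, and the nearest value is that of compound 1 at 80.6%, which lies within the usual scatter of the method; the two readings therefore count as the same within what this assay can resolve, and no order should be read into them.

Compound 3 `CCc1ccc(SCc2ccc(C(=O)Nc3ccccc3N)cc2)cc1` has not yet been measured. It is built from compound 2 by a small swap: ethyl in place of methoxy on an aromatic carbon. Among the measured compounds there is no pair that differs only in this way, so nothing directly shows how this swap moves the number. The expectation rests on compound 2 and its value of 70.7% together with the modest size of the exchange. The step that this expectation means is a number 2.7 percentage points lower from compound 2 to compound 3 (within the scatter), which is expected to stay within the scatter rather than beyond it. Compound 3 is therefore estimated at 68%, with a likely range from 50% to 84%.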

Compound 3, percent growth inhibition at one concentration: 91.4%
For compound 3 the middle estimate is 23.4 percentage points below the measured one, outside the stated range (above it).
By their numbers in this assay, from the lowest: compounds 2 and 1 (each within the scatter of the next); then compound 3.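

In this assay, replacing 4-methoxyphenyl with 4-ethylphenyl gives a number 20.7 percentage points higher from compound 2 to compound 3 (beyond the scatter), so this aromatic carbon, para to a large group, is not indifferent to what it carries. Among the compounds shown here, this is the first comparison here in which only one place differs, and it shows that two groups with the same number of heavy atoms cannot be treated as interchangeable at this position: the change removes an oxygen and its hydrogen-bond acceptor, and puts a carbon in their place. Nothing available explains why the growth inhibition shifts with this swap.

The compounds shown cannot separate a benefit specific to ethyl from a simple benefit of losing methoxy, and a longer chain such as propyl, or an amine or a chlorine atom at the same carbon, would help to tell these readings apart. Going by these compounds, it also remains open whether the same swap would have a similar effect on the core of compound 1, which differs from compound 2 in more than one place.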